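The source may report more compounds than this note shows. Statements on the series, on what has been measured and on what is new or still open speak of the compounds shown alone.

The series is a small set of chalcones that share one core, read out in a functional assay on HaCaT cells (Homo sapiens), read by fluorescence and BrdU incorporation, with a stated time of 48 h, tested at 25 uM; a higher number here means a weaker effect of the compound at the concentration tested, a lower number a stronger effect. Compound 1 `COc1cc(OC)c(C(=O)/C=C/c2ccc(Cl)cc2)c(OC)c1` gives 0% in this assay. Compound 2 `COc1cccc(/C=C/C(=O)c2c(O)cc(OC)cc2OC)c1` gives 8%, which lies within the scatter of the value for compound 1, so the two cannot be told apart. Compound 3 `COc1cc(O)c(C(=O)/C=C/c2ccccc2SC)c(OC)c1` gives 30%, a value beyond the scatter from that of compound 1. On the numbers at hand, compound 1 thus sits at the low end of the range, tied with compound 2 and clearly apart from compound 3.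

Compound 4 `COc1cc(OC)c(C(=O)/C=C/c2ccccc2)c(OC)c1` has not been measured yet. It differs from compound 1 in one place: hydrogen in place of chloro on an aromatic carbon. Among the compounds with values here, no measured pair in this set shows this same change, so its effect has to be guessed from the neighbourhood. Since compound 1 gives 0%, there is no room for a lower number, and the expectation is that the step of a number 12 percentage points higher from compound 1 to compound 4 (beyond the scatter) is small, either none beyond the scatter or a modest move toward a weaker effect. Compound 4 is therefore expected to give about 12% in this assay, with a plausible range from 0% to 38%.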

Compound 4, a percentage reported as activity, at one concentration (the size of the read-out at that concentration, not a potency): 0.1%
Compound 4: middle estimate off by 11.9 percentage points, on the high side; the range from low to high includes it.
By their numbers in this assay, from the lowest: compounds 1, 4 and 2 (each within the scatter of the next); then compound 3.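

In this assay, within the data shown here, hydrogen in place of chloro on this aromatic carbon, para to a large group, gives a number 0.1 percentage points higher from compound 1 to compound 4 (within the scatter), the first single change that can be read in this set. The chloro group at this position is therefore not required for the low number of compound 1 , which stands at 0%, since 4-chlorophenyl to phenyl leaves the read-out unchanged within the scatter. Nothing at hand offers an explanation for this result.

With both compounds at the bottom of the range, this single pair cannot show whether any group at this position would give a higher number. As far as these compounds go, it remains open whether an amine or a carboxylic acid in place of the chloro group would leave the read-out equally unchanged.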